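The source may report more compounds than this note shows. Statements on the series, on what has been measured and on what is new or still open speak of the compounds shown alone.

Compound 1, `COc1cccc2c1c(C(=O)/C=C(\O)C(=O)O)cn2Cc1ccc(F)c(F)c1`: 71000 nM.
Compound 2, `COc1cccc2c1c(C(=O)/C=C(\O)C(=O)O)cn2Cc1ccc(F)c(F)c1F`: 22800 nM.

Both numbers come from an ADME assay on MT4 cells (Homo sapiens) for cytotoxicity, read by MTT assay; a higher number here means that more compound is tolerated, a lower number that less compound is tolerated. Among the measured compounds shown here, compound 2 stands at the lowest of the two numbers, and its only neighbour is compound 1. For the measured compounds named here, the single step between the two, a 3.1-fold lower number from compound 1 to compound 2 (0.49 log units; beyond the scatter), came with fluoro in place of hydrogen on an aromatic carbon and was modest, though beyond the scatter.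

Compound 3, `COc1cccc2c1c(C(=O)/C=C(\O)C(=O)O)cn2Cc1cc(F)c(F)c(F)c1`, differs from compound 2 by 3,4,5-trifluorophenyl in place of 2,3,4-trifluorophenyl on a saturated chain carbon bound to an aromatic nitrogen. Going by the values given here, the step from compound 1 to compound 2 adds a fluorine rather than moving one, so it bears only loosely on this change, and no measured step relocates fluorines around the ring. Compound 3 is therefore expected to show no step beyond the scatter in this assay, no change at the digits printed from compound 2 to compound 3 (within the scatter). Compound 3 is estimated at 22800 nM in this assay, within a range from 8000 nM to 65000 nM.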

Compound 3, half-maximal cytotoxic concentration: 23300 nM
Beside the measured number, compound 3's estimate is 1.0-fold (0.01 log units) below it; low and high end bracket the measured number.
By their numbers in this assay, from the lowest: compounds 2 and 3 (each within the scatter of the next); then compound 1.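

In this assay, the step of a 1.0-fold higher number from compound 2 to compound 3 (0.01 log units; within the scatter) came with 3,4,5-trifluorophenyl in place of 2,3,4-trifluorophenyl on a saturated chain carbon bound to an aromatic nitrogen, so this rearrangement of the three fluorines left the number unchanged within the scatter. The step of a 3.0-fold lower number from compound 1 to compound 3 (0.48 log units; beyond the scatter), with fluoro in place of hydrogen on an aromatic carbon, shows that a lower number than that of compound 1 is not confined to the 2,3,4-trifluorophenyl group. Nothing given here accounts for either step.

The compounds shown carry only fluoro on this aromatic ring, so it remains open how this assay would respond to a chloro or a trifluoromethyl group there. Also open, going by these compounds, is whether the same steps would hold with an amide in place of the carboxylic acid.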